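This account rests on a few compounds, and the source may have more. Where it says the series, first, only, none or still open, it means among the compounds named here.

For the measured compounds named here, in a functional assay on NCI-H460 cells (Homo sapiens) for cytotoxicity, read by MTT assay, with a stated time of 68 h (on this read-out lower numbers stand for stronger inhibition and higher numbers for weaker inhibition), compound 1 `O=C(Nc1cccc(-c2ccccc2C(F)(F)F)c1)C(Cl)Cl` gives 7550 nM, the only plain number among the three values reported. Compound 2 `COC(=O)c1ccc(-c2cccc(NC(=O)C(Cl)Cl)c2)cc1` gives only a limit of the assay, > 50000 nM. Compound 3 `COc1cccc(-c2cc(NC(=O)C(Cl)Cl)cc(-c3cccc(OC)c3)c2)c1` likewise gives only a limit of the assay, > 30000 nM. Compound 4 `O=C(Nc1cccc(-c2ccccc2Cl)c1)C(Cl)Cl` differs from compound 1 by chloro in place of trifluoromethyl on an aromatic carbon, the place being an aromatic carbon of a six-membered aromatic ring of carbon only, ortho to a large group. Going by the values given here, no measured pair shares this change. In this assay the expected step is a 1.3-fold higher number from compound 1 to compound 4 (0.12 log units; within the scatter), which stays within the usual scatter and points in no clear direction. Compound 4 is therefore estimated at 10000 nM, with a range from 3500 nM to 30000 nM.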

Compound 4, half-maximal inhibitory concentration: > 50000 nM
Compound 4: a limit, no number; the forecaster's own chance of this, stated with the estimate: 20%; middle value at least 5.0-fold (0.69 log units) from the limit.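

In this assay, chloro does not stand in for trifluoromethyl at this place, on an aromatic carbon ortho to a large group: the change gives an at least 6.6-fold higher number from compound 1 to compound 4 (0.82 log units; beyond the scatter). For the compounds shown here, the earlier compounds offered no single-place comparison, and this pair is the first to show that the measurable activity of compound 1 depends on the group here. Compound 4 gives only a limit, which leaves compound 1 the sole compound with a plain number: the limit of > 50000 nM in this assay, at which 2 of the 4 values shown sit.

Going by these compounds, the full size of the step remains open. So does whether a methyl or a nitrile at this place would keep the activity of compound 1.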